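Replacing the propyl-linked chlorophenyl by a dichlorophenyl on the piperazine nitrogen

This account rests on a few compounds, and the source may have more. Where it says the series, first, only, none or still open, it means among the compounds named here.

Measured compounds:
compound 1 `Nc1scc(CN2CCN(c3ccncc3)CC2)c1C(=O)c1ccc(Cl)cc1` gives -15%;
compound 2 `Nc1scc(CN2CCN(CCCc3ccc(Cl)cc3)CC2)c1C(=O)c1ccc(Cl)cc1` gives -76%.

In a functional assay on CHO cells with adenosine receptor A1 (Homo sapiens) as the target, read by cAMP accumulation and immunoassay, with a stated time of 6 min, tested at 10 uM (on this read-out higher numbers stand for a weaker effect at the one concentration tested and lower numbers for a stronger effect), compound 2 stands lowest of the two numbers shown, below compound 1 by a number 61 percentage points lower from compound 1 to compound 2 (beyond the scatter). Compound 3 `Nc1scc(CN2CCN(c3cc(Cl)ccc3Cl)CC2)c1C(=O)c1ccc(Cl)cc1` differs from compound 2 by 2,5-dichlorophenyl in place of 3-(4-chlorophenyl)propyl on an amine nitrogen in a ring. The step from compound 1 to compound 2 bears on this change, since compound 1 likewise carries a six-membered aromatic ring on that ring nitrogen and gave the higher number; the step was large. Compound 3 is therefore expected to move back upward by a number 36 percentage points higher from compound 2 to compound 3 (beyond the scatter), though not fully, as the entering ring carries two chlorines. Compound 3 is estimated at -40%, ranging from -75% to -5%.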

Compound 3, a percentage reported as activity, at one concentration (the size of the read-out at that concentration, not a potency): -62%
Compound 3: the middle estimate sits 22 percentage points above what was measured, within the range that was stated.
By their numbers in this assay, from the lowest: compound 2; then compound 3; then compound 1.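

With a ring set directly on the ring nitrogen in this assay, the outcome depends on which ring it is: 2,5-dichlorophenyl in place of pyridin-4-yl gives a number 47 percentage points lower from compound 1 to compound 3 (beyond the scatter). The propyl chain is therefore not needed for most of the lower number, as removing the chain and exchanging the ring gives only a number 14 percentage points higher from compound 2 to compound 3 (beyond the scatter). Nothing given here accounts for either step. Still open, going by these compounds, is how a shorter benzyl link, or a directly attached phenyl ring with a single chlorine, would read on this nitrogen.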